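The source may hold more compounds than are shown below. What is called first, only, known or untested is meant among the compounds shown, and "the series" means these compounds.

Compound 1 `COc1cccc2nnn(CC(=O)N[C@@H](C)c3ccc(C)cc3)c(=O)c12`: 16 mL/min/kg
Compound 2 `COc1ccc2nnn(CC(=O)N[C@@H](C)c3ccc(C)cc3)c(=O)c2c1`: 17 mL/min/kg

In an ADME assay on cells (Hepatocyte, Homo sapiens) for metabolic stability (a higher number here means faster removal of the compound, a lower number slower removal), compound 2 gives 17 mL/min/kg and compound 1 gives 16 mL/min/kg. These two values lie within the scatter of each other, so compound 2 cannot be told apart from compound 1 in this assay.

The next compound is compound 3 `Cc1ccc([C@H](C)NC(=O)Cn2nnc3ccc(C)cc3c2=O)cc1`, which has methyl in place of methoxy on an aromatic carbon of compound 2: methyl in place of methoxy on an aromatic carbon. Going by the values given here, no measured step covers this change, so no direction is supported by data. The expectation rests on compound 2 at 17 mL/min/kg, with a small rise at most and nothing beyond the scatter. The expected step is a 1.1-fold higher number from compound 2 to compound 3 (0.05 log units; within the scatter). The estimated value for compound 3 is 19 mL/min/kg, with an expected range of 10 mL/min/kg to 35 mL/min/kg.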

Compound 3, clearance: 33 mL/min/kg
Compound 3: middle estimate off by 1.7-fold (0.24 log units), on the low side, within the range that was stated.
By their numbers in this assay, from the lowest: compounds 1, 2 and 3 (each within the scatter of the next, the first and the last beyond it).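

In this assay, methyl in place of methoxy on this aromatic carbon gives a 1.9-fold higher number from compound 2 to compound 3 (0.29 log units; within the scatter). Going by these compounds alone, this is the first reading of a group other than methoxy at this place, on the ring of carbon only in the fused system, and it does not separate methyl from methoxy. Within the data shown here, removing the oxygen and its hydrogen-bond acceptor therefore gives no step that can be told from repeat measurements in this pair. Nothing available bears on the size of this step.

On these data alone, whether an amine, a carboxylic acid or a longer alkoxy chain on this carbon would give a step beyond the scatter remains open. Also open, as far as these compounds go, is whether methyl in place of methoxy would read the same on the aromatic carbon that carries methoxy in compound 1.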